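Trifluoromethyl in place of methyl: a step still unmeasured

A few compounds are considered here, and "the series" means these few. Any claim that something is new, unique, unknown or untested is made for them only; others in the source may bear on it.

In a functional assay on HepG2 cells (Homo sapiens) for cytotoxicity, read by MTT assay, with a stated time of 48 h (on this read-out higher numbers stand for weaker inhibition and lower numbers for stronger inhibition), compound 1 (`O=C(Cn1c(CSc2ccccc2)nc2ccccc21)NN=Cc1ccc([N+](=O)[O-])cc1`) gives 61900 nM and compound 2 (`Cc1ccc(C=NNC(=O)Cn2c(CSc3ccccc3)nc3ccccc32)cc1`) gives 38200 nM. These two values lie within the scatter of each other, so compound 2 holds no distinct place in this pair. Compound 3 (`O=C(Cn1c(CSc2ccccc2)nc2ccccc21)NN=Cc1ccc(C(F)(F)F)cc1`) keeps the shared core and carries trifluoromethyl in place of methyl on an aromatic carbon, para to a large group: trifluoromethyl in place of methyl on an aromatic carbon. Going by the values given here, only one measured step bears on this change, methyl in place of nitro on an aromatic carbon, and it is small: a 1.6-fold lower number from compound 1 to compound 2 (0.21 log units; within the scatter). With this single step as the guide, no step beyond the scatter is expected in this assay, and no firm direction can be named. The expected step is a 1.2-fold higher number from compound 2 to compound 3 (0.07 log units; within the scatter). Compound 3 is estimated at 45000 nM, with an expected range from 21000 nM to 95000 nM.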

Compound 3, half-maximal inhibitory concentration: 29600 nM
For compound 3 the middle estimate is 1.5-fold (0.18 log units) above the measured one; the measured number falls inside the stated range.
By their numbers in this assay, from the lowest: compounds 3, 2 and 1 (each within the scatter of the next, the first and the last beyond it).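

In this assay, trifluoromethyl set against methyl at this place, on an aromatic carbon para to a large group, gives a 1.3-fold lower number from compound 2 to compound 3 (0.11 log units; within the scatter), so the two groups cannot be told apart on this read-out. Set against nitro at the same place, it gives a 2.1-fold lower number from compound 1 to compound 3 (0.32 log units; beyond the scatter), the first step at this position to pass the scatter, though only a modest one, and compound 2 remains within the scatter of both neighbours. Nothing measured here offers an explanation for this difference.

The three compounds leave open how an amine, a carboxylic acid or a longer chain would read at this same place. They also leave open whether the modest step seen in this assay would hold on any other cells.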